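Phenoxybutoxy acyl series: carboxyphenyl change on compound 2

The source may hold more compounds than are shown below. What is called first, only, known or untested is meant among the compounds shown, and "the series" means these compounds.

Measured so far in an assay on HEK293 cells for positive allosteric modulation of metabotropic glutamate receptor 2 (Rattus norvegicus), read by thallium flux, with a stated time of 2.5 min; on this read-out higher numbers stand for an effect only at larger amounts of compound and lower numbers for an effect already at smaller amounts:
compound 1 `Cc1c(OCCCCOc2ccccc2C(=O)O)ccc(C(=O)CC2CCCC2)c1C`: 2580 nM
compound 2 `Cc1c(OCCCCOc2ccccc2C(=O)O)ccc(C(=O)CC2CCCC2)c1O`: 335 nM

Within the data shown here, compound 2 gives the lowest of the two numbers; the only measured step, a 7.7-fold lower number from compound 1 to compound 2 (0.89 log units; beyond the scatter), is a change of hydroxy in place of methyl on an aromatic carbon and does not touch the carboxyphenyl end of the chain.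

Compound 3 `Cc1c(OCCCCOc2ccc(C(=O)O)c(Cl)c2)ccc(C(=O)CC2CCCC2)c1O` differs from compound 2 by 4-carboxy-3-chlorophenyl in place of 2-carboxyphenyl on an oxygen on a saturated carbon. Among the measured compounds shown here, no measured step concerns this part of the molecule, so the size and direction of the step in this assay cannot be read from the data; the carboxy group and the aryl ether both remain, the new chlorine is the only added atom. A step of uncertain direction, of modest size at most, is expected, with the estimate left near compound 2.

For compound 3 the expected value in this assay is 500 nM, in the range 150 nM to 2500 nM, which is an expected step of a 1.5-fold higher number from compound 2 to compound 3 (0.17 log units; within the scatter).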

Compound 3, half-maximal effective concentration: 510 nM
Compound 3: the middle estimate sits 1.0-fold (0.01 log units) below what was measured; the range from low to high includes it.
By their numbers in this assay, from the lowest: compounds 2 and 3 (each within the scatter of the next); then compound 1.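

In this assay, the swap of 2-carboxyphenyl for 4-carboxy-3-chlorophenyl on the oxygen on a saturated carbon gives a 1.5-fold higher number from compound 2 to compound 3 (0.18 log units; within the scatter). This end of the chain therefore accepts a different carboxyphenyl pattern with an added chlorine, and the two compounds cannot be told apart on this read-out. No measured data bear on why the swap leaves the number within the scatter.

Among these compounds, the single step changes the carboxy placement and adds chlorine together, so their separate contributions cannot be read; 4-carboxyphenyl without the chlorine would separate them. Also open, on these data alone, is whether this end of the chain needs the carboxylic acid at all, which a tetrazole in its place would test.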